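The source may report more compounds than this note shows. Statements on the series, on what has been measured and on what is new or still open speak of the compounds shown alone.

Compound 1 `NC(=S)N1CCc2c(OCCCCCOc3ccc(Cl)cc3)cccc21`: > 50000 nM in an ADME assay on Huh-7 cells (Homo sapiens) for cytotoxicity; on this read-out lower numbers stand for higher toxicity in this test and higher numbers for lower toxicity in this test
Compound 2 `O=C(NC(=S)N1CCc2c(OCCCCCOc3ccc(Cl)cc3)cccc21)c1cccc([N+](=O)[O-])c1`: 12100 nM in this assay

The value of compound 1 is a limit of the assay, not a number; the one limit in the set, (the limit of > 50000 nM in this assay, at which 1 of the 2 values shown sits), belongs to it. Compound 2 gives the only number, so on the numbers shown it stands alone, below the limit at which compound 1 sits. Within the data shown here, the single measured step, an at least 4.1-fold lower number from compound 1 to compound 2 (0.61 log units; beyond the scatter), is the whole of what the measured compounds say.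

Compound 3 `O=S(=O)(NC(=S)N1CCc2c(OCCCCCOc3ccc(Cl)cc3)cccc21)c1ccccc1` differs from compound 2 in one place: phenylsulfonyl in place of (3-nitrophenyl)carbonyl on an amide-type nitrogen. The step from compound 1 to compound 2 bears on it only loosely, since it tells what a carbonyl-type group entering on that nitrogen did, not what exchanging it for phenylsulfonyl does. Because that step, an at least 4.1-fold lower number from compound 1 to compound 2 (0.61 log units; beyond the scatter), was at least modest, a substituted nitrogen is expected to keep compound 3 away from the limit, while the loss of the nitro group leaves its direction open. Compound 3 is therefore expected to give 18000 nM, with a range from 7000 nM to 50000 nM. The expected step from compound 2 is a 1.5-fold higher number from compound 2 to compound 3 (0.17 log units; within the scatter), which would lie within the scatter.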

Compound 3, half-maximal cytotoxic concentration: > 50000 nM
Compound 3: no number, only a limit (the forecaster's own chance of this, stated with the estimate: 30%); middle value at least 2.7-fold (0.44 log units) from the limit.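

A group on the amide-type nitrogen is therefore not enough on its own to bring the number down: in this assay, phenylsulfonyl in place of (3-nitrophenyl)carbonyl gives an at least 4.1-fold higher number from compound 2 to compound 3 (0.61 log units; beyond the scatter). The step from compound 1 to compound 2 could not show this, and of the two groups shown on that nitrogen, only (3-nitrophenyl)carbonyl gives a number under the limit. The value of compound 3 is a limit of the assay, as is that of compound 1, so the step between those two cannot be read and the set still holds a single number: the limit of > 50000 nM in this assay, at which 2 of the 3 values shown sit.

The exchange from compound 2 to compound 3 replaces the carbonyl with a sulfonyl and removes the nitro group in one move, so the compounds shown do not tell which of these changes goes with the higher number. Going by these compounds, a plain phenylcarbonyl group, a (3-nitrophenyl)sulfonyl group or an amine in place of the nitro group on the (3-nitrophenyl)carbonyl would each bear on that question, and how any of them would read here remains open.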